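From 3-bromophenyl to 4-chlorophenyl on the amine nitrogen

A few compounds are considered here, and "the series" means these few. Any claim that something is new, unique, unknown or untested is made for them only; others in the source may bear on it.

Measured so far in a functional assay on L1210 cells (Mus musculus) for inhibition; a higher number here means a weaker inhibitor, a lower number a stronger inhibitor:
- compound 1 `C#CCN(Cc1ccc2nc(C)nc(O)c2c1)c1ccccc1`: > 6500 nM, a limit of the assay and not a number
- compound 2 `C#CCN(Cc1ccc2nc(C)nc(O)c2c1)c1cccc(Br)c1`: 1800 nM

Going by the values given here, compound 2 holds the only actual number, 1800 nM. Compound 1 gives only a limit, (the limit of > 6500 nM in this assay, at which 1 of the 2 values shown sits).

The next compound is compound 3 `C#CCN(Cc1ccc2nc(C)nc(O)c2c1)c1ccc(Cl)cc1`, which carries 4-chlorophenyl in place of 3-bromophenyl on an amine nitrogen. Among the compounds with values here, the one measured step that bears on this change is an at least 3.6-fold lower number from compound 1 to compound 2 (0.55 log units; beyond the scatter). That step came with bromo in place of hydrogen on an aromatic carbon, and its size is only a floor. Compound 3 still carries a halogen on the phenyl, so most of the gain in an at least 3.6-fold lower number from compound 1 to compound 2 (0.55 log units; beyond the scatter) is expected to remain. Within the data shown here, no measurement yet separates the kind of halogen from its position, so the expectation is loose. The estimated step is a 1.4-fold higher number from compound 2 to compound 3 (0.14 log units; within the scatter), with a small loss more likely than a gain. For compound 3 the expected value in this assay is 2500 nM, with an estimated range of 800 nM to 7000 nM.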

Compound 3, half-maximal inhibitory concentration: > 4000 nM
Compound 3: no number, only a limit; the forecaster's own chance of this, stated with the estimate: 20%; middle value at least 1.6-fold (0.20 log units) from the limit.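

In this assay, putting 4-chlorophenyl in place of 3-bromophenyl on the amine nitrogen gives an at least 2.2-fold higher number from compound 2 to compound 3 (0.34 log units; beyond the scatter), so a halogen on the phenyl is not in itself enough to keep the activity of compound 2. Among the compounds shown, 3-bromophenyl is the only group on this nitrogen that yields an actual number, and compound 3 joins compound 1 in giving only a limit and not a number: the limit of > 4000 nM in this assay, at which 1 of the 3 values shown sits.
Compound 1 and compound 3 both stand as limits, and the step between them cannot be read.

This change alters the kind of halogen and its place on the phenyl together, and the compounds shown do not separate the two; a phenyl with chloro where 3-bromophenyl carries bromo, or with bromo where 4-chlorophenyl carries chloro, would tell them apart. As far as these compounds go, how far compound 3 actually falls from compound 2 also remains open, as does the outcome with a fluoro, a methyl or a methoxy group on the phenyl.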